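This account rests on a few compounds, and the source may have more. Where it says the series, first, only, none or still open, it means among the compounds named here.

Measured compounds: compound 1 `CNc1nc(C)c(-c2nc3ccccc3s2)c(N[C@@H]2C[C@H](CO)[C@@H](O)[C@H]2O)n1` gives > 25000 nM; compound 2 `Cc1nc(NCC(C)C)nc(N[C@@H]2C[C@H](CO)[C@@H](O)[C@H]2O)c1-c1nc2ccccc2s1` gives 10000 nM; compound 3 `Cc1nc(NCCNS(C)(=O)=O)nc(N[C@@H]2C[C@H](CO)[C@@H](O)[C@H]2O)c1-c1nc2ccccc2s1` gives > 25000 nM in an ADME assay on cells (Homo sapiens) for cytotoxicity, read by polymerase chain reaction, with a stated time of 3 days; a lower number here means that less compound is tolerated, a higher number that more compound is tolerated.

Compound 3 reports only a limit of the assay, not a number. It sits at the limit of > 25000 nM in this assay, at which 2 of the 3 values shown sit. The unmeasured compound 4 `Cc1nc(NCCCC(F)(F)F)nc(N[C@@H]2C[C@H](CO)[C@@H](O)[C@H]2O)c1-c1nc2ccccc2s1` differs from compound 3 by 2,2,2-trifluoroethyl in place of methanesulfonamido on a saturated chain carbon, two bonds along the chain from a nitrogen on an aromatic ring. Two measured steps end at compound 3: an at least 2.5-fold higher number from compound 2 to compound 3 (0.39 log units; beyond the scatter), and a step that the two limits leave unreadable from compound 1 to compound 3. The change to compound 4 removes the methanesulfonamido group whose arrival raised the number in that first step, so compound 4 is expected to come back toward compound 2 at 10000 nM. Compound 4 is therefore estimated at 12000 nM, between 5000 nM and 25000 nM. This estimate means an expected step of an at least 2.0-fold lower number from compound 3 to compound 4 (0.31 log units; beyond the scatter).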

Compound 4, half-maximal cytotoxic concentration: 3000 nM
Compound 4: the middle estimate sits 4.0-fold (0.60 log units) above what was measured, outside the stated range (below it).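

In this assay, 2,2,2-trifluoroethyl in place of methanesulfonamido gives an at least 8.3-fold lower number from compound 3 to compound 4 (0.92 log units; beyond the scatter), and compound 3 holds only a limit of the assay. The same chain also lies beyond the isopropyl-ended chain, with a 3.3-fold lower number from compound 2 to compound 4 (0.52 log units; beyond the scatter), and beyond hydrogen at that carbon, with an at least 8.3-fold lower number from compound 1 to compound 4 (0.92 log units; beyond the scatter). Losing the methanesulfonamido group therefore does more than return the number to the level of compound 2, and nothing shown gives a cause for this.

The compounds shown leave open whether the fluorines or the chain itself lowers the number. From the compounds shown here alone, a plain butyl chain would separate the two, and an amine or carboxylic acid at the chain end remains untested here.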